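Small Fluorine Shift on a Well-Tolerated Amide

A few compounds are considered here, and "the series" means these few. Any claim that something is new, unique, unknown or untested is made for them only; others in the source may bear on it.

In an ADME assay on LLC-MK2 cells (Macaca mulatta) for cytotoxicity, read by spectrophotometry and crystal violet staining, with a stated time of 4 days (a lower number here means that less compound is tolerated, a higher number that more compound is tolerated), compound 1 (`CC(C)n1ncc2c(C(=O)Nc3c(F)cccc3F)cc(-c3cccs3)nc21`) gives > 200000 nM, which is a limit of the assay and not a number. Compound 2 (`CC(C)n1ncc2c(C(=O)N3CCc4cc(F)ccc43)cc(-c3cccs3)nc21`) gives > 200000 nM, again a limit. Compound 1 therefore stands at the limit of > 200000 nM in this assay, at which 2 of the 3 values shown sit. Among the measured compounds shown here, compound 3 (`CC(C)n1ncc2c(C(=O)Nc3ccccc3F)cc(-c3ccccn3)nc21`) is the only one with an actual number, 100000 nM.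

Compound 4 (`CC(C)n1ncc2c(C(=O)Nc3ccc(F)cc3F)cc(-c3cccs3)nc21`) has not yet been measured. It keeps the core of compound 1 and changes in one place, on an amide-type nitrogen: 2,4-difluorophenyl in place of 2,6-difluorophenyl on an amide-type nitrogen. The two fluorine atoms stay, and 2,4-difluorophenyl takes the place of 2,6-difluorophenyl. For the measured compounds named here, no measured pair shows what this swap does in this assay. With the limit of compound 1 at > 200000 nM, no change beyond the usual scatter is expected for compound 4. The expected step is a number no higher from compound 1 to compound 4 (the limit leaves the size open), and the reading may well be a limit again. For compound 4 the estimated value is 200000 nM, with an expected range from 100000 nM to 400000 nM.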

Compound 4, half-maximal cytotoxic concentration: > 200000 nM
Compound 4 was reported as a limit; the forecaster's own chance of this, stated with the estimate: 70%; the middle value lies on the limit itself.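

Compound 1 and compound 4 both read as limits in this assay, so no step can be read between them. Whether 2,4-difluorophenyl in place of 2,6-difluorophenyl changes what is tolerated at all stays open, because both readings stop at the same point: the limit of > 200000 nM in this assay, at which 3 of the 4 values shown sit.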